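The source may hold more compounds than are shown below. What is called first, only, known or untested is meant among the compounds shown, and "the series" means these compounds.

Measured compounds:
compound 1 `CC(=O)N1N=C(c2ccc(-n3nc(C)n(N)c3=O)cc2)CC1c1ccccc1`, which in an assay on isolated protein for inhibition of pancreatic alpha-amylase (Homo sapiens), with a stated time of 10 min, tested at 1 mg/mL (a lower number here means less inhibition, a higher number more inhibition at the concentration tested (going by the name of the read-out)), gives 129%
compound 2 `COc1ccc(C2CC(c3ccc(-n4nc(C)n(N)c4=O)cc3)=NN2C(C)=O)cc1`, which in this assay gives 96.5%

For the measured compounds named here, compound 2 stands lowest of the two numbers; its nearest neighbour is compound 1, and the one step in hand, a number 32.5 percentage points lower from compound 1 to compound 2 (beyond the scatter), lies beyond the scatter. Compound 3 `CC(=O)N1N=C(c2ccc(-n3nc(C)n(N)c3=O)cc2)CC1c1ccc(O)cc1` is the next member and is still to be tested in this assay. It differs from compound 2 by hydrogen in place of methyl on an oxygen on an aromatic ring.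

Going by the values given here, only one measured step bears on this: a number 32.5 percentage points lower from compound 1 to compound 2 (beyond the scatter), where the methoxy entered on the aromatic carbon and the number fell by a large amount. The change to compound 3 keeps the oxygen on that ring but removes the methyl, so it is neither a return to compound 1 nor the same step again. Among the compounds with values here, no measured pair shows a methoxy to hydroxy change. The expectation is therefore a small rise, a number 9.5 percentage points higher from compound 2 to compound 3 (within the scatter), not clearly beyond the scatter, with a wide range. Compound 3 is estimated at 106%, between 86% and 126%.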

Compound 3, a percentage reported as inhibition, at one concentration (the size of the read-out at that concentration, not a potency): 76.7%
For compound 3 the middle estimate is 29.3 percentage points above the measured one, and the stated range ends above it.
By their numbers in this assay, from the lowest: compound 3; then compound 2; then compound 1.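

In this assay, hydroxy on this aromatic carbon also gives a lower number than hydrogen, a number 52.3 percentage points lower from compound 1 to compound 3 (beyond the scatter), so the fall now holds for both oxygen groups in hand and not for methoxy alone. The methyl on that oxygen also matters to the read-out: its removal gives a number 19.8 percentage points lower from compound 2 to compound 3 (beyond the scatter), which separates 4-hydroxyphenyl from 4-methoxyphenyl and, within these three compounds only, places the numbers in the order hydrogen, methoxy, hydroxy from highest to lowest. Nothing available bears on the reason for this order.

Going by these compounds, whether the fall belongs to oxygen groups specifically or to any group on this aromatic carbon remains open, and an amine, a carboxylic acid or a fluorine at the same place would separate those readings. Also open, on these data alone, is whether the number keeps moving with the group on the oxygen, for which a longer chain such as ethoxy would be the next comparison against the methoxy of compound 2 and the hydroxy of compound 3.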